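From compound 3 to compound 4: a furan-3-yl swap

The source may hold more compounds than are shown below. What is called first, only, known or untested is meant among the compounds shown, and "the series" means these compounds.

In an ADME assay on HepG2 cells (Homo sapiens) for cytotoxicity, read by CellTiter-Glo and resazurin assay, with a stated time of 72 h (a higher number here means that more compound is needed for the effect, a lower number that less compound is needed), compound 1 `CCOC(=O)CCCCCOc1cccc(CN(C(=O)c2ccc(-c3cccc(N(C)C)c3)cc2)C(C)C)c1` gives > 26000 nM, which is a limit and not a number. Compound 2 `CCOC(=O)CCCCCOc1cccc(CN(C(=O)c2ccc(-c3ccc4ccccc4c3)cc2)C(C)C)c1` gives > 26000 nM, again a limit. On these data alone, compound 3 `CCOC(=O)CCCCCOc1cccc(CN(C(=O)c2ccc(-c3cccc(-c4ccccc4)c3)cc2)C(C)C)c1` gives > 26000 nM, also a limit, so its exact place on the scale is unknown. Compound 4 `CCOC(=O)CCCCCOc1cccc(CN(C(=O)c2ccc(-c3ccoc3)cc2)C(C)C)c1` carries one change: furan-3-yl in place of 3-phenylphenyl on an aromatic carbon. Furan-3-yl replaces 3-phenylphenyl at the same place. Three measured steps changed this same group: a step that the two limits leave unreadable from compound 1 to compound 2, a step that the two limits leave unreadable from compound 1 to compound 3 and a step that the two limits leave unreadable from compound 2 to compound 3. None has a readable size, and together they show (the limit of > 26000 nM in this assay, at which 3 of the 3 values shown sit). No step beyond the scatter is therefore expected, in either direction, and the estimate is a step that the limit leaves unreadable from compound 3 to compound 4. The expected value for compound 4 is 30000 nM, with an estimated range from 15000 nM to 60000 nM.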

Compound 4, half-maximal effective concentration: > 26000 nM
Compound 4 was reported as a limit (the forecaster's own chance of this, stated with the estimate: 80%); the middle value does not contradict the limit.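

Going by these compounds alone, no step among compound 1, compound 2, compound 3 and compound 4 can be read, as each result is only a limit: the limit of > 26000 nM in this assay, at which 4 of the 4 values shown sit. The compounds shown leave open the actual concentration at which any of them reaches the half-maximal effect in this assay, and whether changing this group shifts it.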